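Swapping the Ester Arm of Compound 1

The compounds below may be only part of what the source reports. "The series", "measured", "known", "first", "only" and "open" are said of these compounds alone.

Among the compounds with values here, compound 1 `CCCCOC(=O)Cc1c(C(C)C)nc(CCCC)n(Cc2ccc(-c3ccccc3-c3noc(=O)[nH]3)cc2)c1=O` gives 21.6% in an ADME assay on microsomes from liver (Mus musculus) for metabolic stability, with a stated time of 30 min (on this read-out higher numbers stand for a more stable compound and lower numbers for a less stable compound), the highest of the three numbers measured so far; compound 3 `CCCCc1nc(C)c(CC(=O)OC2CC2)c(=O)n1Cc1ccc(-c2ccccc2-c2noc(=O)[nH]2)cc1` gives 12.8%, which lies within the scatter of that, while compound 2 `CCCCOC(=O)Cc1c(C)nc(CCCC)n(Cc2ccc(-c3ccccc3-c3noc(=O)[nH]3)cc2)c1=O` gives 10.2%, and the step of a number 11.4 percentage points lower from compound 1 to compound 2 (beyond the scatter) lies beyond the scatter. Compound 4 `CCCCc1nc(C(C)C)c(C(C)C(=O)OCC)c(=O)n1Cc1ccc(-c2ccccc2-c2noc(=O)[nH]2)cc1` differs from compound 1 by 1-(ethoxycarbonyl)ethyl in place of (butoxycarbonyl)methyl on an aromatic carbon. Within the data shown here, the only measured step that changes the group on the oxygen next to a carbonyl, a number 2.6 percentage points higher from compound 2 to compound 3 (within the scatter), stays within the scatter, and the step from compound 1 to compound 2 concerns a different position. For compound 4 a similarly small step is therefore expected, a number 0.6 percentage points lower from compound 1 to compound 4 (within the scatter), with no direction beyond the scatter. Compound 4 is estimated at 21%, in a range from 9% to 34%.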

Compound 4, percent of the compound remaining: 28%
The estimate for compound 4 lay 7 percentage points below the measured number; low and high end bracket the measured number.
By their numbers in this assay, from the lowest: compounds 2, 3, 1 and 4 (each within the scatter of the next, the first and the last beyond it).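

In this assay, replacing (butoxycarbonyl)methyl with 1-(ethoxycarbonyl)ethyl on this aromatic carbon gives a number 6.4 percentage points higher from compound 1 to compound 4 (within the scatter), so the two arms cannot be told apart on this read-out. Within the data shown here, this is the first step in which the whole arm changes, and it alters both the chain on the oxygen and the carbon carrying the carbonyl group, so the compounds cannot divide the step between those two edits. Nothing available offers a reason for the outcome.

Still open, going by these compounds, is how a carboxylic acid or an amide would read at this position, and whether the 1-(ethoxycarbonyl)ethyl arm behaves alike with methyl in place of isopropyl.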